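The source may hold more compounds than are shown below. What is called first, only, known or untested is meant among the compounds shown, and "the series" means these compounds.

Three compounds have so far been measured in a functional assay on DU-145 cells (Homo sapiens) for inhibition, read by MTT assay, with stated times of 18 h and 4 h; a higher number here means a weaker inhibitor, a lower number a stronger inhibitor:

compound 1 `CCCCCCCCCCOP(=O)(O)OCCSC(=S)N1CCCC1` gives 46100 nM
compound 2 `CCCCCCCCCCOP(=O)(O)OCCSC(=S)N1CCCCC1` gives 29300 nM
compound 3 `CCCCCCOP(=O)(O)OCCSC(=S)N1CCCC1` gives only a limit of the assay, > 100000 nM

Compound 2 differs from compound 1 by piperidin-1-yl in place of pyrrolidin-1-yl on a thiocarbonyl carbon, and that step reads a 1.6-fold lower number from compound 1 to compound 2 (0.20 log units; within the scatter). Compound 3 differs from compound 1 by hydrogen in place of butyl on a saturated chain carbon, six bonds along the chain from an oxygen on an unsaturated carbon, a step of an at least 2.1-fold higher number from compound 1 to compound 3 (0.33 log units; beyond the scatter), leaving compound 3 at the limit of > 100000 nM in this assay, at which 1 of the 3 values shown sits. Compound 4 `CCCCCCOP(=O)(O)OCCSC(=S)N1CCCCC1` is not yet measured; it differs from compound 3 by piperidin-1-yl in place of pyrrolidin-1-yl on a thiocarbonyl carbon, the same change as that between compound 1 and compound 2, set on the shorter-chain core. The step from compound 3 to compound 4 in this assay is expected to be a step that the limit leaves unreadable from compound 3 to compound 4, because the like step gave a 1.6-fold lower number from compound 1 to compound 2 (0.20 log units; within the scatter). Compound 4 is therefore estimated at 120000 nM, from 60000 nM to 300000 nM, and may again be reported only as a limit.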

Compound 4, half-maximal inhibitory concentration: > 100000 nM
Compound 4 ended at the assay's limit; the forecaster's own chance of this, stated with the estimate: 70%; the middle value is on the limit's open side.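

Replacing butyl with hydrogen on a saturated chain carbon, six bonds along the chain from an oxygen on an unsaturated carbon, gives an at least 3.4-fold higher number from compound 2 to compound 4 (0.53 log units; beyond the scatter). The change thus carries over in direction to the second core, but its size there is only a minimum, and nothing shows that the two steps are equal or unequal: the same change on two cores in this assay, an at least 2.1-fold higher number (0.33 log units; beyond the scatter) from compound 1 to compound 3 and an at least 3.4-fold higher number (0.53 log units; beyond the scatter) from compound 2 to compound 4; the limit leaves it open whether they differ

The step from compound 3 to compound 4 cannot be read, as both compounds sit at a limit: the limit of > 100000 nM in this assay, at which 2 of the 4 values shown sit.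

The compounds shown leave open how an octyl or a dodecyl chain would read on either core. They also leave open whether a morpholine in place of piperidin-1-yl would keep the reading of compound 2.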